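This account rests on a few compounds, and the source may have more. Where it says the series, first, only, none or still open, it means among the compounds named here.

Series notes on the shared core. Compound 3 `COc1cccc(C(=O)N2CCCC(C(=O)Nc3ccc(Cl)cc3)C2)c1` carries a methoxy group on an aromatic carbon of the core. In an ADME assay on PC-3 cells (Homo sapiens) for cytotoxicity, read by WST assay, tested at 100 uM (on this read-out lower numbers stand for less inhibition and higher numbers for more inhibition at the one concentration tested (going by the name of the read-out)), compound 3 gives 0%. Compound 1 `O=C(Nc1ccc(Cl)cc1)C1CCCN(C(=O)c2cccc([N+](=O)[O-])c2)C1` gives 0% in this assay, and compound 2 `O=C(c1ccccc1)c1cccc(C(=O)N2CCCC(C(=O)Nc3ccc(Cl)cc3)C2)c1` gives 0%. Compound 3 therefore stands level with compounds 1 and 2 at the digits recorded, with compound 1 nearest and compound 2 furthest, both without any change beyond the scatter. The measured steps are all flat: no change at the digits printed from compound 1 to compound 2 (within the scatter), no change at the digits printed from compound 1 to compound 3 (within the scatter) and no change at the digits printed from compound 2 to compound 3 (within the scatter). Each exchange of the group at this aromatic carbon has so far left the read-out unmoved.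

Compound 4 `Cc1nc(-c2cccc(C(=O)N3CCCC(C(=O)Nc4ccc(Cl)cc4)C3)c2)cs1` differs from compound 3 in one place: 2-methyl-1,3-thiazol-4-yl in place of methoxy on an aromatic carbon. Within the data shown here, the entering group is of a kind not yet tested among the measured compounds, so the steps that bear on the change are those into compound 3 from compound 1 and from compound 2, both within the scatter. No movement beyond the scatter is expected in this assay. The expected step is no change at the digits printed from compound 3 to compound 4 (within the scatter), that is, none beyond the scatter. Compound 4 is estimated at 0%, with a range from -5% to 15%.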

Compound 4, a percentage reported as inhibition, at one concentration (the size of the read-out at that concentration, not a potency): 1%
Compound 4: the middle estimate sits 1 percentage points below what was measured; low and high end bracket the measured number.
By their numbers in this assay, from the lowest: compounds 1, 2, 3 and 4 (each within the scatter of the next).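

With 2-methyl-1,3-thiazol-4-yl, a five-membered aromatic ring with 2 hetero atoms now stands at this aromatic carbon, and in this assay the exchange stays within the scatter from each of the three earlier groups: methoxy (a number 1 percentage points higher from compound 3 to compound 4 (within the scatter)), benzoyl (a number 1 percentage points higher from compound 2 to compound 4 (within the scatter)) and nitro (a number 1 percentage points higher from compound 1 to compound 4 (within the scatter)). Among these compounds, the flat picture at this position therefore extends to an aromatic heterocycle, a kind of group the earlier compounds did not include, and the exchange of methoxy for this group of 6 heavy atoms, with sulfur and nitrogen entering, does not take the read-out beyond the scatter. No measurement is at hand that would account for this flatness.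

All four compounds sit together within the scatter, so these data show no group at this aromatic carbon that separates itself from the others in this assay, and they give no ranking of the four groups. Going by these compounds, whether a basic amine such as dimethylamino, a carboxylic acid or a longer chain such as an alkoxyethyl group at this carbon would also stay within the scatter remains open, as does the effect of any exchange elsewhere on the shared core.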